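This account rests on a few compounds, and the source may have more. Where it says the series, first, only, none or still open, it means among the compounds named here.

Measured compounds:
- compound 1, `CC[C@@H](Nc1c(C#N)c(-c2ccc(-c3ccc(F)cc3)cc2)nc2cnccc12)C(N)=O`, 2.7
- compound 2, `CCOc1ccccc1-c1ccc(-c2nc3cnccc3cc2C#N)cc1`, 3.8
- compound 3, `CN(CC(N)=O)c1c(C#N)c(-c2ccc(Br)cc2)nc2cnccc12`, 2.1

Three compounds built on the same core have been run through a physicochemical assay for lipophilicity, read by HPLC, at pH 7.5; a higher number here means a more lipophilic compound, a lower number a more polar compound. Compound 2 gives 3.8, the highest of the three. Compound 1 gives 2.7, the second highest; its nearest neighbour is compound 3, which gives 2.1, a gap beyond the scatter, and compound 2 lies further away, also beyond the scatter. No two of the measured compounds differ in a single place, so no single step can be read off among them.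

Compound 4, `CC[C@@H](Nc1c(C#N)c(-c2ccc(-c3ccc(OC)cc3)cc2)nc2cnccc12)C(N)=O`, has not yet been measured in this assay. It differs from compound 1 in one place: methoxy in place of fluoro on an aromatic carbon. The group that leaves carries no hydrogen-bond acceptor, the one that enters carries one; both sit on the same aromatic carbon, para to a large group. With no comparable exchange among the measured compounds, the expectation rests on the value of compound 1 alone, 2.7. The step from compound 1 to compound 4 is expected to be small, at most a slight fall, and likely within the scatter: a number 0.10 log units lower from compound 1 to compound 4 (within the scatter). Compound 4 is therefore estimated to come out near 2.6, between 2.2 and 3.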

Compound 4, distribution coefficient: 2.7
The estimate for compound 4 lay 0.10 log units below the measured number, within the range that was stated.
By their numbers in this assay, from the lowest: compound 3; then compounds 1 and 4 (each within the scatter of the next); then compound 2.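

In this assay, among the compounds shown here, putting methoxy in place of fluoro on an aromatic carbon, para to a large group, gives no change at the digits printed from compound 1 to compound 4 (within the scatter), and this is the first step that can be read at a single place. For the compounds shown here, no earlier pair differed in one place only, so the position could not be judged until now: here, 4-fluorophenyl and 4-methoxyphenyl give the same reading at the digits printed, even though the entering group carries a hydrogen-bond acceptor and the leaving group carries none. No measured evidence bears on why the two groups read alike.

The compounds shown leave open whether other groups on this aromatic carbon, such as an amine, a carboxylic acid or a longer alkoxy chain, would also leave the number in place or would move it beyond the scatter. They also leave open whether the exchange of fluoro for methoxy would give a similar step on a compound with a different group on the shared core.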